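The source may hold more compounds than are shown below. What is called first, only, known or untested is meant among the compounds shown, and "the series" means these compounds.

In an in vitro ADME assay on blood (Homo sapiens) for metabolic stability (on this read-out higher numbers stand for a longer-lived compound and lower numbers for a shorter-lived compound), compound 1 (`CCOc1cccc2c1C(=O)N(COC(=O)c1c(Cl)cccc1Cl)S2(=O)=O`) gives 0.167 h, the lower of the two numbers at hand, while compound 2 (`COc1cc(OC)c2c(c1)S(=O)(=O)N(COC(=O)c1c(Cl)cccc1Cl)C2=O`) gives 0.5 h. Compound 3 (`CCOc1cc(OCC)c2c(c1)S(=O)(=O)N(COC(=O)c1c(Cl)cccc1Cl)C2=O`) has not yet been measured. It departs from compound 1 by ethoxy in place of hydrogen on an aromatic carbon, with ethoxy in place of hydrogen on an aromatic carbon. Within the data shown here, no measured pair isolates this change, so the guide is thin, but the reading of compound 2 at 0.5 h points towards a rise in this assay. A modest lengthening is expected, an estimated 2.1-fold higher number from compound 1 to compound 3 (0.32 log units; beyond the scatter). For compound 3 the expected half-life is 0.35 h, with an estimated range of 0.13 h to 0.9 h.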

Compound 3, half-life: 1.63 h
Compound 3: the middle estimate sits 4.7-fold (0.67 log units) below what was measured, outside the stated range (above it).
By their numbers in this assay, from the lowest: compound 1; then compound 2; then compound 3.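

In this assay, ethoxy in place of hydrogen on an aromatic carbon gives a 9.8-fold higher number from compound 1 to compound 3 (0.99 log units; beyond the scatter), a rise towards a longer-lived compound that lies beyond the usual scatter. The earlier compounds shown here offered no step that isolated this change, so this is the only direct sign that this position, para to a fused ring and meta to an ethoxy group, can shift the half-life. Going by these compounds, whether a longer chain, an amine or a carboxylic acid at this position would move the half-life in the same direction remains open. No measurement at hand bears on why the half-life rises.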